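Methoxy to hydroxy on compound 2: expected outcome

A few compounds are considered here, and "the series" means these few. Any claim that something is new, unique, unknown or untested is made for them only; others in the source may bear on it.

Of the compounds shown here, three have been measured in a functional assay on KM12 cells (Homo sapiens) for inhibition, read by sulforhodamine B assay, with a stated time of 48 h; on this read-out higher numbers stand for lower toxicity in this test and lower numbers for higher toxicity in this test. Compound 2 `COc1cc(-c2nn(-c3cccc(NC(=O)Nc4cc(C(F)(F)F)cc(C(F)(F)F)c4)c3)cc2-c2ccncc2)ccc1Cl` gives 3390 nM in this assay, the only figure in the set that is a number rather than a limit. Compound 1 `O=C(Nc1cccc(-n2cc(-c3ccncc3)c(-c3ccc(Cl)c(O)c3)n2)c1)Nc1cccc(C(F)(F)F)c1` reaches only the limit > 32500 nM in this assay. Compound 3 `COc1cc(-c2nn(-c3cccc(NC(=O)Nc4cccc(C(F)(F)F)c4)c3)cc2-c2ccncc2)ccc1Cl` likewise stops at the limit > 50000 nM in this assay. Among the measured compounds shown here, the one readable step is an at least 14-fold higher number from compound 2 to compound 3 (1.16 log units; beyond the scatter), tied to hydrogen in place of trifluoromethyl on an aromatic carbon. The step that the two limits leave unreadable from compound 1 to compound 3, methyl in place of hydrogen on an oxygen on an aromatic ring, carries no size because both of its ends sit at a limit of > 32500 nM in this assay, at which 1 of the 3 values shown sits (the limit of > 50000 nM in this assay, at which 1 of the 3 values shown sits).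

Compound 4 `O=C(Nc1cccc(-n2cc(-c3ccncc3)c(-c3ccc(Cl)c(O)c3)n2)c1)Nc1cc(C(F)(F)F)cc(C(F)(F)F)c1` is not yet measured; it differs from compound 2 by hydrogen in place of methyl on an oxygen on an aromatic ring, that is methoxy to hydroxy, 4-chloro-3-methoxyphenyl to 4-chloro-3-hydroxyphenyl. For the measured compounds named here, the only measured step on the same oxygen is a step that the two limits leave unreadable from compound 1 to compound 3, which gives no reading in either direction. Going by the values given here, the change therefore has no usable precedent in this assay, and the expectation is no step beyond the scatter, held with wide uncertainty. For compound 4 the expected value in this assay is 4000 nM with a range of 1500 nM to 15000 nM. This estimate means an expected step of a 1.2-fold higher number from compound 2 to compound 4 (0.07 log units; within the scatter).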

Compound 4, concentration lethal to 50% of the cells: 4060 nM
Compound 4: middle estimate off by 1.0-fold (0.01 log units), on the low side; low and high end bracket the measured number.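

In this assay, among the compounds shown here, the change at this oxygen now has a readable size for the first time: a 1.2-fold higher number from compound 2 to compound 4 (0.08 log units; within the scatter), so on the core of compound 2 the methoxy and hydroxy forms are not told apart by this read-out. The trifluoromethyl change, until now sized only on the methoxy core, also reads on the hydroxy core: an at least 8.0-fold lower number from compound 1 to compound 4 (0.90 log units; beyond the scatter), which puts the number with the added trifluoromethyl on the lower side in both pairs. The two pairs agree in direction, but their sizes cannot be set against each other: the same change on two cores in this assay, an at least 14-fold higher number (1.16 log units; beyond the scatter) from compound 2 to compound 3 and an at least 8.0-fold higher number (0.90 log units; beyond the scatter) from compound 4 to compound 1; the limit leaves it open whether they differ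

On the core with a single trifluoromethyl the same oxygen change still cannot be read, with both of its ends at limits of the assay, so the absence of a step beyond the scatter holds only for the pair of compound 2 and compound 4. Whether an ethyl group or a longer chain ending in an amine on this oxygen would move the number beyond the scatter stays open, as the compounds shown carry only methyl or hydrogen there.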